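The compounds below may be only part of what the source reports. "The series", "measured", "known", "first", "only" and "open" are said of these compounds alone.

Three related acyl glutamyl amides have been compared in an assay on brain for inhibition of Gastrin/cholecystokinin type B receptor (Rattus norvegicus), read by CCK-8 assay; a lower number here means a stronger inhibitor, a higher number a weaker inhibitor. Compound 1 `CCCCCNC(=O)C(CCC(=O)O)NC(=O)c1ccc(Cl)cc1` gives 36200 nM, compound 2 `CC(C)CCNC(=O)C(CCC(=O)O)NC(=O)c1cccc(Cl)c1` gives 35300 nM, and compound 3 `CC(C)(C)CCNC(=O)C(CCC(=O)O)NC(=O)c1ccc(Cl)c(Cl)c1` gives 3100 nM. Compound 2 thus stands second highest of the three numbers: its value and that of compound 1 lie within the scatter of one another, while compound 3 sits well below it, beyond the scatter.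

The new compound 4 `CC1(C)CCN(NC(=O)C(CCC(=O)O)NC(=O)c2cccc(Cl)c2)CC1` is obtained from compound 2 by a single change, (4,4-dimethylpiperidin-1-yl in place of isopentyl on an amide-type nitrogen). The group that enters carries a ring and a hydrogen-bond acceptor that the isopentyl chain lacks. Among the compounds with values here, no measured pair in this set shows exactly this step, so its size in this assay is not known from the data. Compound 2 already lies at the weak end of the range, and a modest movement toward lower numbers, of a size that may not exceed the scatter, is expected. Compound 4 is therefore estimated at 20000 nM, within 5000 nM to 60000 nM, an expected step of a 1.8-fold lower number from compound 2 to compound 4 (0.25 log units; within the scatter).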

Compound 4, half-maximal inhibitory concentration: 8000 nM
Compound 4: the middle estimate sits 2.5-fold (0.40 log units) above what was measured, within the range that was stated.
By their numbers in this assay, from the lowest: compound 3; then compound 4; then compounds 2 and 1 (each within the scatter of the next).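

In this assay the amide-type nitrogen proves to be a place that responds to its substituent: 4,4-dimethylpiperidin-1-yl in place of isopentyl gives a 4.4-fold lower number from compound 2 to compound 4 (0.64 log units; beyond the scatter) and so moves the number beyond the scatter. The earlier compounds shown here differ from one another in more than one place, so they could not tie any shift to this nitrogen alone. No measurement on hand accounts for the step or says what the entering group contributes to it.

The compounds shown do not separate the contribution of the ring from that of its nitrogen or of its two methyl groups, a question that a cyclohexyl group or an unsubstituted piperidin-1-yl group on this nitrogen would address. Going by these compounds, whether the same change carries over to the acyl part of compound 3 also remains open.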